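Hydroxymethyl for trifluoromethyl on a piperazine-linked aryl group

The source may report more compounds than this note shows. Statements on the series, on what has been measured and on what is new or still open speak of the compounds shown alone.

Compound 1 `N#Cc1ccc(N2CCN(S(=O)(=O)c3ccc4c(c3)CC(=O)N4)CC2)cc1` and compound 2 `O=C1Cc2cc(S(=O)(=O)N3CCN(c4ccc(C(F)(F)F)cc4)CC3)ccc2N1` share the same core and differ only in the group on the distal aromatic ring. In an assay on isolated protein for inhibition of lysosomal alpha-glucosidase (Homo sapiens), read by fluorescence, with stated times of 5 min and 45 min (a lower number here means a stronger inhibitor, a higher number a weaker inhibitor), compound 1 gives 2910 nM, a weak inhibitor. Compound 2, carrying trifluoromethyl in that position, was reported in this assay as "not active" (no number reported), so no number stands for it and its place on the scale cannot be set; it can only be said that it falls outside the measured range that compound 1 occupies.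

Compound 3 `O=C1Cc2cc(S(=O)(=O)N3CCN(c4ccc(CO)cc4)CC3)ccc2N1` is the next variation. Its change from compound 2 is hydroxymethyl in place of trifluoromethyl on an aromatic carbon, that is, on an aromatic carbon of a six-membered aromatic ring of carbon only, para to a large group. With no number for compound 2, no step size can be computed for this pair. Given that the closest measured analogue, compound 1, sits at 2910 nM, compound 3 is expected to be a weak inhibitor at best in this assay, with a fair chance of again being reported without a number. The estimate for compound 3 in this assay is 6000 nM, within a range of 1200 nM to 30000 nM.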

Compound 3, half-maximal inhibitory concentration: 13000 nM
Compound 3: middle estimate off by 2.2-fold (0.34 log units), on the low side, within the range that was stated.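

In this assay the change of hydroxymethyl in place of cyano on an aromatic carbon gives a 4.5-fold higher number from compound 1 to compound 3 (0.65 log units; beyond the scatter) and so places a second number on the scale at this position, showing that the group there can shift inhibition by a measurable amount while the compound stays a weak inhibitor. Hydroxymethyl, with one hydrogen-bond donor and one hydrogen-bond acceptor, yields a number where trifluoromethyl in compound 2 yielded none, but the step from compound 2 to compound 3 cannot be read, and it can only be said that compound 3 falls within a measured range and compound 2 does not. Nothing available accounts for the differences among these three groups.

The compounds shown leave open how an amine, a carboxylic acid or a longer chain ending in hydroxyl would read at this place on the ring. For the compounds shown here, they also leave open whether the order of cyano and hydroxymethyl seen here would hold on any core other than the one shared by these compounds.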